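Furan-3-yl to thiophen-3-yl at the assay limit

The compounds below may be only part of what the source reports. "The series", "measured", "known", "first", "only" and "open" are said of these compounds alone.

In an ADME assay on MRC5 cells (Homo sapiens), read by MTT assay, with a stated time of 72 h (on this read-out lower numbers stand for stronger inhibition and higher numbers for weaker inhibition), compound 3 `Cc1nc(N)c2c(-c3ccoc3)cn([C@@H]3O[C@H](CO)[C@@H](O)[C@H]3O)c2n1` gives > 100000 nM, which is a limit of the assay and not a number. Compound 1 `Cc1ncnc2c1c(-c1cccs1)cn2[C@@H]1O[C@H](CO)[C@@H](O)[C@H]1O` gives > 100000 nM, also a limit. The position shared by these two is the limit of > 100000 nM in this assay, at which 2 of the 3 values shown sit. Within the data shown here, compound 2 `C#Cc1cn([C@@H]2O[C@H](CO)[C@@H](O)[C@H]2O)c2ncnc(C)c12` gives 1440 nM, the only true number so far, and it stands apart from the other two.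

The next compound, compound 4 `Cc1nc(N)c2c(-c3ccsc3)cn([C@@H]3O[C@H](CO)[C@@H](O)[C@H]3O)c2n1`, is not yet measured. It changes one place of compound 3: thiophen-3-yl in place of furan-3-yl on an aromatic carbon.

Among the measured compounds shown here, the only measured step is an at least 69-fold lower number from compound 1 to compound 2 (1.84 log units; beyond the scatter). That step is large, but it exchanges a thiophen-2-yl ring for ethynyl on a different core, so it says little about exchanging one five-membered aromatic ring for another. The closer hint is that compound 1, with its thiophen-2-yl group, stands at the limit of > 100000 nM. No step beyond the scatter is therefore expected in this assay, and any measurable shift would be towards a lower number.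

The expected step is an at least 1.1-fold lower number from compound 3 to compound 4 (0.04 log units; that floor lies within the scatter). For compound 4 the estimate is 90000 nM, with an expected range from 25000 nM to 100000 nM.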

Compound 4, half-maximal inhibitory concentration: > 100000 nM
Compound 4: no number, only a limit (the forecaster's own chance of this, stated with the estimate: 70%); at least 1.1-fold (0.04 log units) between middle value and limit.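

In this assay compound 4 gives > 100000 nM, a limit of the assay and not a number. Compound 3 also gives a limit, so no step can be read from compound 3 to compound 4: the limit of > 100000 nM in this assay, at which 3 of the 4 values shown sit.

The compounds shown leave open whether thiophen-3-yl and furan-3-yl differ at all on the shared core in this assay.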